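Replacing the carboxy group of compound 2 with hydrogen

The compounds below may be only part of what the source reports. "The series", "measured", "known", "first", "only" and "open" are said of these compounds alone.

Working notes on the series. In a functional assay on SGC-7901 cells (Homo sapiens) for antiproliferative activity, read by MTT assay, with a stated time of 72 h (a higher number here means a weaker inhibitor, a lower number a stronger inhibitor), compound 1 (`CCOC(=O)c1cc(-c2ccc(OC)cc2)c(-c2cc(OC)c(OC)c(OC)c2)s1`) gives 6820 nM, compound 2 (`COc1ccc(-c2cc(C(=O)O)sc2-c2cc(OC)c(OC)c(OC)c2)cc1`) gives 4220 nM and compound 3 (`COc1ccc(-c2cc(C(=O)O)sc2-c2cc(OC)c(OC)c(OC)c2)cc1O`) gives 17500 nM. Compound 2 holds the lowest number of the three, but compound 1 cannot be told apart from it. Replacing ethyl with hydrogen on the oxygen next to the carbonyl group gave a 1.6-fold lower number from compound 1 to compound 2 (0.21 log units; within the scatter). Adding a hydroxy group on an aromatic carbon gave a 4.1-fold higher number from compound 2 to compound 3 (0.62 log units; beyond the scatter).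

The next compound is compound 4 (`COc1ccc(-c2ccsc2-c2cc(OC)c(OC)c(OC)c2)cc1`), with hydrogen in place of carboxy on an aromatic carbon. For the measured compounds named here, two measured steps bear on it, both only indirectly. The ethyl step, a 1.6-fold lower number from compound 1 to compound 2 (0.21 log units; within the scatter), touches the same group but leaves the carbonyl in place, so it does not test removal of the whole carboxy group. Going by the values given here, the hydroxy step, a 4.1-fold higher number from compound 2 to compound 3 (0.62 log units; beyond the scatter), lies elsewhere and shows only that one small change can move the number modestly. Among the compounds with values here, no measured compound lacks a group at this ring carbon, so the direction remains open. A step of about the scatter is expected, with a weak lean to a lower number.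

The expected step is a 1.7-fold lower number from compound 2 to compound 4 (0.23 log units; within the scatter). Compound 4 is estimated at 2500 nM, with an expected range of 300 nM to 15000 nM.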

Compound 4, half-maximal inhibitory concentration: 2740 nM
Compound 4: middle estimate off by 1.1-fold (0.04 log units), on the low side, and the stated range covers the measured number.
By their numbers in this assay, from the lowest: compounds 4, 2 and 1 (each within the scatter of the next, the first and the last beyond it); then compound 3.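

In this assay this ring carbon now has a measured case with no group on it, and the step (a 1.5-fold lower number from compound 2 to compound 4 (0.19 log units; within the scatter)) leaves compound 2 and compound 4 indistinguishable, so the carboxy group is not required for a number of this size. For the compounds shown here, removing the whole ethoxycarbonyl group gives the first step at this carbon that lies beyond the scatter (a 2.5-fold lower number from compound 1 to compound 4 (0.40 log units; beyond the scatter)), although it is only modest and neither of the two smaller steps that link these compounds through compound 2 can be read as a change on its own. Nothing measured on these compounds accounts for either step.

On these data alone, it remains open whether any group at this carbon gives a number clearly lower than hydrogen does, and an amine, a methyl group, a primary amide or a fluorine atom there would test this. As far as these compounds go, it is also open whether the hydroxy change seen with the carboxy group in place (a 4.1-fold higher number from compound 2 to compound 3 (0.62 log units; beyond the scatter)) would have the same size on the core of compound 4, where that group is absent.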